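The source may hold more compounds than are shown below. What is called first, only, known or untested is meant among the compounds shown, and "the series" means these compounds.

Measured in an in vitro ADME assay on microsomes from liver (Simiiformes); on this read-out higher numbers stand for a longer-lived compound and lower numbers for a shorter-lived compound:

compound 1 `CCc1cc(CCCOc2c(C)cc(-c3noc(C4CC4)n3)cc2C)on1`: 0.9 h
compound 2 `CCc1cc(CCCOc2c(C)cc(-c3noc(C(F)(F)F)n3)cc2C)on1`: > 2.5 h, a limit of the assay and not a number
compound 3 `Cc1cc(-c2noc(C(F)(F)F)n2)cc(C)c1OCCCc1cc(CO)no1`: > 2.5 h, likewise only a limit

Compound 2 and compound 1 share one core and differ in one place: cyclopropyl in place of trifluoromethyl on an aromatic carbon. In this assay that change gave an at least 2.7-fold lower number from compound 2 to compound 1 (0.44 log units; beyond the scatter). Compound 3 stands on a different core; how the two cores differ is hydroxy in place of methyl on a saturated chain carbon bound to an aromatic carbon. For this pair a step that the two limits leave unreadable from compound 2 to compound 3; what can be said is the limit of > 2.5 h in this assay, at which 2 of the 3 values shown sit.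

Compound 4 `Cc1cc(-c2noc(C3CC3)n2)cc(C)c1OCCCc1cc(CO)no1` has not been measured. It stands to compound 3 as compound 1 stands to compound 2, by the same change: cyclopropyl in place of trifluoromethyl on an aromatic carbon. For compound 3 only a limit is known in this assay, so the size of the step to compound 4 cannot be read from a number. In this assay compound 4 is expected at 1 h, estimated to fall between 0.4 h and 2.5 h. This expected step is an at least 2.5-fold lower number from compound 3 to compound 4 (0.39 log units; beyond the scatter). That expectation rests on compound 1, which gave 0.9 h after the same change from compound 2.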

Compound 4, half-life: > 2.5 h
Compound 4 was reported as a limit (the forecaster's own chance of this, stated with the estimate: 20%); middle value at least 2.5-fold (0.39 log units) away from the limit.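

In this assay compound 4 gives > 2.5 h, a limit of the assay and not a number. The change from trifluoromethyl to cyclopropyl gave an at least 2.7-fold lower number from compound 2 to compound 1 (0.44 log units; beyond the scatter), but on the core of compound 3 the same change left no readable loss, and with cyclopropyl held fixed, hydroxy in place of methyl gave an at least 2.7-fold higher number from compound 1 to compound 4 (0.44 log units; beyond the scatter). This shows that the drop seen on the core of compound 1 did not carry over to a value that the assay could read, but it does not show that the change has no effect on the core of compound 3, since the steps between limits cannot be read and any difference between compound 3 and compound 4 stays hidden: the limit of > 2.5 h in this assay, at which 3 of the 4 values shown sit.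

The compounds shown leave open how a carboxylic acid or an amine in place of the hydroxy would behave alongside cyclopropyl. They also leave open whether a longer chain in place of cyclopropyl on the 1,2,4-oxadiazol-3-yl group would keep compound 4's limit.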